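Dimethoxyphenyl for phenyl at the ring carbon next to oxygen

The source may report more compounds than this note shows. Statements on the series, on what has been measured and on what is new or still open speak of the compounds shown alone.

Measured so far:
compound 1, `COc1ccc(CCC[C@@H]2C[C@@H]([C@@H](O)c3ccc(OC)c(OC)c3)CO[C@H]2c2ccc(OC)c(OC)c2)cc1OC`, 35700 nM
compound 2, `COc1ccc(/C=C/C[C@@H]2C[C@@H]([C@@H](O)c3ccc(OC)c(OC)c3)CO[C@H]2c2ccccc2)cc1OC`, 16100 nM

Both numbers come from a functional assay on HeLa cells (Homo sapiens) for cytotoxicity, read by WST assay, with a stated time of 48 h; a higher number here means a weaker inhibitor, a lower number a stronger inhibitor. Compound 2 gives 16100 nM, the lower of the two numbers; the nearest is compound 1 at 35700 nM, a gap beyond the usual scatter. The two differ in more than one place, so the comparison is only of the two values as they stand and not a single step.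

Compound 3, `COc1ccc(/C=C/C[C@@H]2C[C@@H]([C@@H](O)c3ccc(OC)c(OC)c3)CO[C@H]2c2ccc(OC)c(OC)c2)cc1OC`, is not yet measured. It keeps the three-carbon unsaturated linker of compound 2 and changes one site: 3,4-dimethoxyphenyl in place of phenyl on a saturated ring carbon. The entering group is the same one carried by compound 1 at that position of the shared core, and compound 1 stands higher than compound 2. Whether that difference belongs to the aryl group or to the saturated linker of compound 1 cannot be separated on two compounds.

For compound 3 the number is expected to sit between the two measured values, with a step of a 1.5-fold higher number from compound 2 to compound 3 (0.17 log units; within the scatter) that may not clear the scatter. The estimate for compound 3 in this assay is 24000 nM, ranging from 8000 nM to 70000 nM.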

Compound 3, half-maximal inhibitory concentration: 30600 nM
Compound 3: middle estimate off by 1.3-fold (0.11 log units), on the low side; measured number inside the range.
By their numbers in this assay, from the lowest: compounds 2, 3 and 1 (each within the scatter of the next, the first and the last beyond it).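

Changing phenyl to 3,4-dimethoxyphenyl on the saturated ring carbon next to the ring oxygen, with the unsaturated linker kept, gives a step within the scatter in this assay (a 1.9-fold higher number from compound 2 to compound 3 (0.28 log units; within the scatter)), and with 3,4-dimethoxyphenyl held at that carbon, 2-(3,4-dimethoxyphenyl)ethenyl in place of 2-(3,4-dimethoxyphenyl)ethyl also stays within the scatter (a 1.2-fold lower number from compound 1 to compound 3 (0.07 log units; within the scatter)). This position therefore accepts the larger aryl group with no change that can be read in this assay, and the gap between the printed values of compound 1 and compound 2 can be assigned to neither single change alone. Nothing available speaks to the reason for these numbers.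

Still open, going by these compounds, is whether a different group at this ring carbon, such as a pyridine ring, a single methoxy or a hydroxyl on the phenyl ring, would move the number beyond the scatter, and whether an amine or a carboxylic acid on the linker would do so. On these data alone, all three numbers come from this assay alone, so whether the same flat picture holds in other cell lines or at other exposure times remains unknown.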